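A few compounds are considered here, and "the series" means these few. Any claim that something is new, unique, unknown or untested is made for them only; others in the source may bear on it.

Measured so far:
Compound 1, `C=CCn1c(SCC(=O)Nc2ccc(C(C)=O)cc2)nnc1-c1ccccc1`, gives 70% in a functional assay on the whole organism (strain albino) for inhibition, with Rattus norvegicus as the target, read by paw edema, with stated times of 30 min and 4 h, at a dose of 0.28 mmol/kg by the oral route; a lower number here means less inhibition, a higher number more inhibition at the dose given (going by the name of the read-out).
Compound 2, `COc1cc(-c2nnc(SCC(=O)Nc3ccc(/C(C)=N/O)cc3)n2-c2ccccc2)cc(OC)c1OC`, gives 75% in this assay.

On the numbers shown, compound 2 stands level with compound 1: the gap between the two readings lies within the scatter of repeated measurements, so neither can be set above the other. For the measured compounds named here, the two measured compounds differ from each other in several places at once, and no step between them isolates a single change; nothing here shows what one methoxy group alone does in this assay.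

Compound 3, `COc1ccc(-c2nnc(SCC(=O)Nc3ccc(/C(C)=N/O)cc3)n2-c2ccccc2)cc1OC`, is the next compound to be measured in this assay. It differs from compound 2 in one place: hydrogen in place of methoxy on an aromatic carbon.

Going by the values given here, with no single-change step in hand, the expectation for the step from compound 2 to compound 3 in this assay is a number 5 percentage points lower from compound 2 to compound 3 (within the scatter), a small move downward or none beyond the scatter. Compound 3 is therefore estimated at 70% in this assay, with a range from 55% to 85%.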

Compound 3, a percentage reported as inhibition, in the whole organism at one dose (the size of the read-out at that dose, not a potency): 79%
Compound 3: middle estimate off by 9 percentage points, on the low side, within the range that was stated.
By their numbers in this assay, from the lowest: compounds 1, 2 and 3 (each within the scatter of the next).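

In this assay, for the compounds shown here, the change from 3,4,5-trimethoxyphenyl to 3,4-dimethoxyphenyl, hydrogen in place of methoxy on an aromatic carbon, gives a number 4 percentage points higher from compound 2 to compound 3 (within the scatter) and is the first single-change step. At this position, ortho to a methoxy group and meta to a large group, the methoxy can therefore be exchanged for hydrogen with no difference beyond the scatter at this one dose, although this single step cannot show whether the same holds for the two methoxy groups that remain. No measured evidence on the cause of this outcome is available.

The steps between compound 1 and the other two compounds cannot be read, as compound 1 differs from each of them in several places, and the step from compound 2 to compound 3 says nothing about the effect of other doses. From the compounds shown here alone, it also remains open how an amine, a hydroxyl group, a chlorine atom or a longer alkoxy chain would read at this position, and what removing the remaining methoxy groups would do.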